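The source may hold more compounds than are shown below. What is called first, only, known or untested is meant among the compounds shown, and "the series" means these compounds.

Of the compounds shown here, three have so far been measured in a functional assay on NCI-H460 cells (Homo sapiens) for cytotoxicity, read by MTT assay, with a stated time of 72 h; a higher number here means a weaker inhibitor, a lower number a stronger inhibitor. Compound 1 `CN(C)CCn1cnnc1-c1cc(Oc2ccc(NC(=O)N/N=C/c3cc(C(C)(C)C)cc(C(C)(C)C)c3O)cc2F)ccn1` gives 590 nM. Compound 2 `CN(C)CCn1cnnc1-c1cc(Oc2ccc(NC(=O)N/N=C/c3ccccc3O[N+](=O)[O-])cc2F)ccn1` gives 1270 nM, the second highest of the three numbers, lying beyond the scatter from compound 1 and far below compound 3. Compound 3 `Cn1ncnc1-c1cc(Oc2ccc(NC(=O)N/N=C/c3ccccc3)cc2F)ccn1` gives 52200 nM, the highest number of the set. No two of these three differ in only one place, so no single clean step can be read from the measured compounds.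

Compound 4 `CN(C)CCn1cnnc1-c1cc(Oc2ccc(NC(=O)N/N=C/c3c(O)ccc4ccccc34)cc2F)ccn1` has not yet been measured. It differs from compound 2 in one place: 2-hydroxynaphthalen-1-yl in place of 2-(nitrooxy)phenyl on a carbon with a double bond to nitrogen. Compound 1, whose ring at that carbon also carries a hydroxyl rather than a nitrooxy group, gives 590 nM, a somewhat lower number than compound 2. The expected step is therefore a 1.8-fold lower number from compound 2 to compound 4 (0.26 log units; within the scatter), a small move downward that may well stay within the scatter. Compound 4 is estimated at 700 nM, within a range from 250 nM to 2000 nM.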

Compound 4, half-maximal inhibitory concentration: 890 nM
For compound 4 the middle estimate is 1.3-fold (0.10 log units) below the measured one, within the range that was stated.
By their numbers in this assay, from the lowest: compounds 1, 4 and 2 (each within the scatter of the next, the first and the last beyond it); then compound 3.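

In this assay, putting 2-hydroxynaphthalen-1-yl in place of 2-(nitrooxy)phenyl on the carbon with a double bond to nitrogen gives a 1.4-fold lower number from compound 2 to compound 4 (0.15 log units; within the scatter). This position therefore accepts a swap from one six-membered aromatic ring to two, and from a nitrooxy group to a hydroxyl, while the two compounds stay indistinguishable in this measurement. Nothing available here explains why these two different groups read alike.

Going by these compounds, this single step alters the ring system and the oxygen group together, so their separate contributions remain unknown, and a 2-hydroxyphenyl or a plain naphthalen-1-yl group on this carbon would pull them apart. On these data alone, it also remains open how an amine or a carboxylic acid on the ring at this carbon would read.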